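Exchanging azepan-1-yl for piperidin-1-yl at the assay limit

A few compounds are considered here, and "the series" means these few. Any claim that something is new, unique, unknown or untested is made for them only; others in the source may bear on it.

Compound 1, `CCCCCCCCCCCCCCCCOP(=O)(O)OCCSC(=S)N1CCCCCC1`, was tested in a functional assay on MCF7 cells (Homo sapiens) for inhibition, read by MTT assay, with stated times of 18 h and 4 h; a lower number here means a stronger inhibitor, a higher number a weaker inhibitor. In this assay compound 1 gives > 100000 nM, which is a limit of the assay and not a number. Compound 2, `CCCCCCOP(=O)(O)OCCSC(=S)N1CCCCCC1`, has hydrogen in place of decyl on a saturated chain carbon, and compound 2 gives 55000 nM. For the measured compounds named here, that change is the only measured step here, an at least 1.8-fold lower number from compound 1 to compound 2 (0.25 log units; that floor lies within the scatter), and its floor lies within the scatter.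

Compound 3, `CCCCCCCCCCCCCCCCOP(=O)(O)OCCSC(=S)N1CCCCC1`, keeps the chain of compound 1 and differs in the ring: piperidin-1-yl in place of azepan-1-yl on a thiocarbonyl carbon. So piperidin-1-yl takes the place of azepan-1-yl on a thiocarbonyl carbon. Going by the values given here, no measured step covers a change of this group, and the one step available concerns the chain alone. It therefore gives no guide to size or direction, and no step beyond the scatter is expected in this assay. The expected step is a number no higher from compound 1 to compound 3 (the limit leaves the size open). The assay may well report only a limit again. For compound 3 the estimated value is 100000 nM, with an expected range from 40000 nM to 250000 nM.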

Compound 3, half-maximal inhibitory concentration: 29000 nM
Compound 3: the middle estimate sits 3.4-fold (0.54 log units) above what was measured; the whole stated range lies above it.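

In this assay, the group on the thiocarbonyl carbon proves able to move the result: piperidin-1-yl in place of azepan-1-yl gives an at least 3.4-fold lower number from compound 1 to compound 3 (0.53 log units; beyond the scatter). For the compounds shown here, this is the first step that clearly stands beyond the scatter, whereas the chain change alone gave an at least 1.8-fold lower number from compound 1 to compound 2 (0.25 log units; that floor lies within the scatter), so the ring at this position now has a measured effect of its own on the number, while the chain still has none that can be told from noise. Compound 1 stands at a limit and not at a number, so the ring step gives only a floor and its true size remains unknown: the limit of > 100000 nM in this assay, at which 1 of the 3 values shown sits.

Going by these compounds alone, only two rings are compared at this position, which is too few to show a trend, and a pyrrolidin-1-yl or morpholin-4-yl group on the same thiocarbonyl carbon could fit or break any reading drawn from this pair. The change is also shown only with the long chain of compound 1, so whether piperidin-1-yl gives a similar step with the shorter chain of compound 2 stays open.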